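Ethoxy in place of methyl on the carbonyl side chain

The compounds below may be only part of what the source reports. "The series", "measured", "known", "first", "only" and "open" are said of these compounds alone.

Compound 1 `CCn1nc(-c2cccnc2)c2ccccc2c1=O` carries a methyl on the saturated chain carbon bound to an aromatic nitrogen; in an assay on isolated protein (Oryctolagus cuniculus) with Thromboxane-A synthase (Homo sapiens) as the target, tested at 1 uM (a lower number here means less inhibition, a higher number more inhibition at the concentration tested (going by the name of the read-out)), compound 1 gives 87%. Compound 2 `C=CCn1nc(-c2cccnc2)c2ccccc2c1=O` gives 70%, and compound 3 `CC(=O)Cn1nc(-c2cccnc2)c2ccccc2c1=O` gives 13%, the lowest of the three. Both a number 74 percentage points lower from compound 1 to compound 3 (beyond the scatter) and a number 57 percentage points lower from compound 2 to compound 3 (beyond the scatter) were large drops, while a number 17 percentage points lower from compound 1 to compound 2 (beyond the scatter) was modest. Compound 4 `CCOC(=O)Cn1nc(-c2cccnc2)c2ccccc2c1=O` differs from compound 3 in one place: ethoxy in place of methyl on a carbonyl carbon. Among the compounds with values here, no measured step alters a group on the carbonyl carbon itself; the two steps that brought in the acetyl lowered the number sharply, and compound 4 keeps a carbonyl there. The number for compound 4 is expected to stay low, with a number 5 percentage points higher from compound 3 to compound 4 (within the scatter) expected to fall within the scatter. Compound 4 is estimated at 18%, between 4% and 45%.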

Compound 4, a percentage reported as inhibition, at one concentration (the size of the read-out at that concentration, not a potency): 28%
The estimate for compound 4 lay 10 percentage points below the measured number; the measured number falls inside the stated range.
By their numbers in this assay, from the lowest: compound 3; then compound 4; then compound 2; then compound 1.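

The group on the carbonyl carbon matters: ethoxy in place of methyl gives a number 15 percentage points higher from compound 3 to compound 4 (beyond the scatter) as a modest step, the first change seen at this carbon. That gain recovers only part of the loss, since the ethoxycarbonyl group still gives a number 42 percentage points lower from compound 2 to compound 4 (beyond the scatter) and a number 59 percentage points lower from compound 1 to compound 4 (beyond the scatter) as large steps, so both side chains with a carbonyl remain well behind the vinyl and methyl ones. Nothing available explains the effect of ethoxy here. Still open, from the compounds shown here alone, is whether a carboxylic acid, an amide or a longer chain on the carbonyl carbon would recover more of the inhibition.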